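A few compounds are considered here, and "the series" means these few. Any claim that something is new, unique, unknown or untested is made for them only; others in the source may bear on it.

Measured compounds in this series:

Compound 1 `O=C(CCCCCCc1ccccn1)c1ncc(-c2ccccn2)o1` gives 120 nM in an assay for inhibition of Fatty-acid amide hydrolase 1 (Rattus norvegicus); on this read-out higher numbers stand for weaker inhibition and lower numbers for stronger inhibition.
Compound 2 `O=C(CCCCCCc1cccnc1)c1ncc(-c2ccccn2)o1` gives 32 nM in this assay.
Compound 3 `O=C(CCCCSCc1ccccc1)c1ncc(-c2ccccn2)o1` gives 25 nM in this assay.

Compound 3 holds the lowest number of the three, but its gap to compound 2 lies within the scatter, so the two cannot be ordered; only against compound 1 does compound 3 stand apart, with a 4.8-fold lower number from compound 1 to compound 3 (0.68 log units; beyond the scatter). The next step leads to compound 4 `COC(=O)CCCCC(=O)c1ncc(-c2ccccn2)o1`, which differs from compound 3 by methoxycarbonyl in place of benzylsulfanyl on a saturated chain carbon, four bonds along the chain from a carbonyl carbon.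

The steps that touch the same place are a 4.8-fold lower number from compound 1 to compound 3 (0.68 log units; beyond the scatter) and a 1.3-fold lower number from compound 2 to compound 3 (0.11 log units; within the scatter), both exchanges of one ring-bearing chain end for another. Neither removes the ring altogether, so none of them directly mirrors the change to compound 4. The shared core and the carbonyl stay in place, and the chain is cut back to a short ester. With the ring gone, a weaker result is expected rather than a stronger one; the size of that step is uncertain, and the estimated step is a 20-fold higher number from compound 3 to compound 4 (1.30 log units; beyond the scatter). Compound 4 is therefore expected to give about 500 nM in this assay, with a plausible range from 100 nM to 3000 nM.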

Compound 4, inhibition constant: 1800 nM
Estimate against measurement, compound 4: 3.6-fold (0.56 log units) below; measured number inside the range.
By their numbers in this assay, from the lowest: compounds 3 and 2 (each within the scatter of the next); then compound 1; then compound 4.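

For the compounds shown here, at this place, on a saturated chain carbon four bonds along the chain from a carbonyl carbon, the earlier exchanges all kept a ring-bearing end, and methoxycarbonyl is the first end without a ring. In this assay it gives large steps against all three ring-bearing compounds (a 72-fold higher number from compound 3 to compound 4 (1.86 log units; beyond the scatter)) and (a 56-fold higher number from compound 2 to compound 4 (1.75 log units; beyond the scatter)) and (a 15-fold higher number from compound 1 to compound 4 (1.18 log units; beyond the scatter)), so even the ring-bearing end with the highest number stands well apart from this short ester. Nothing measured here explains the size of these steps.

As far as these compounds go, it remains open whether the loss follows from removing the aromatic ring, from shortening the chain end or from the ester itself. A carboxylic acid or an amine at this place, or a longer chain ending in methoxycarbonyl, would help to separate these readings.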